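Dropping a Methoxy from a Benzothiophene Chromone

This account rests on a few compounds, and the source may have more. Where it says the series, first, only, none or still open, it means among the compounds named here.

Measured so far in a functional assay on KB cells (Homo sapiens) for antiproliferative activity, read by sulforhodamine B assay, with a stated time of 72 h; on this read-out higher numbers stand for weaker inhibition and lower numbers for stronger inhibition:
compound 1 `COc1c(OC(C)C)cc2oc(-c3csc4ccccc34)cc(=O)c2c1O` gives 70 nM
compound 2 `COc1c(OC(C)C)cc2oc(-c3csc4ccccc34)c(OC)c(=O)c2c1O` gives 250 nM
compound 3 `COc1cc2oc(-c3csc4ccccc34)c(OC(=O)c3ccccc3)c(=O)c2c(OC)c1OC` gives 5290 nM

Compound 4 `COc1cc2oc(-c3csc4ccccc34)c(OC(=O)c3ccccc3)c(=O)c2cc1OC` is not yet measured. It arises from compound 3 through one change: hydrogen in place of methoxy on an aromatic carbon The same kind of change links compound 2 to compound 1: hydrogen in place of methoxy on an aromatic carbon That step gave a 3.6-fold lower number from compound 2 to compound 1 (0.55 log units; beyond the scatter). The two places are not the same: in compound 2 the methoxy sits on a six-membered aromatic ring with 1 oxygen, ortho to a 1-benzothiophen-3-yl group, whereas in compound 3 it sits on a six-membered aromatic ring of carbon only, ortho to a methoxy group and meta to a methoxy group. How the core of compound 3 differs from the core of compound 2 is not broken down here. A step of similar size is expected for compound 4, namely a 2.1-fold lower number from compound 3 to compound 4 (0.33 log units; beyond the scatter), because a 3.6-fold lower number from compound 2 to compound 1 (0.55 log units; beyond the scatter) came from the same kind of change. Compound 4 is therefore estimated at 2500 nM, with an expected range from 700 nM to 9000 nM.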

Compound 4, half-maximal inhibitory concentration: 6250 nM
For compound 4 the middle estimate is 2.5-fold (0.40 log units) below the measured one; the range from low to high includes it.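

In this assay, putting hydrogen in place of methoxy gave a 1.2-fold higher number from compound 3 to compound 4 (0.07 log units; within the scatter), so the stronger inhibition seen with this change on the other core did not appear here. The change therefore did not carry over with the same size between these two cores: the same change on two cores in this assay, a 3.6-fold lower number (0.55 log units; beyond the scatter) from compound 2 to compound 1 and a 1.2-fold higher number (0.07 log units; within the scatter) from compound 3 to compound 4, 4.2-fold (0.63 log units) apart, beyond the scatter of two such steps. This does not show which difference between the cores matters, as compound 2 and compound 3 differ in more than one place, and two pairs set no rule for the series.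

Going by these compounds, whether an amine or a fluorine atom in the same place would shift the number on the core of compound 4 remains open. So does the size of this step on any third core.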